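Trimming and Branching the Hydroxy Ester Chain

A few compounds are considered here, and "the series" means these few. Any claim that something is new, unique, unknown or untested is made for them only; others in the source may bear on it.

Measured so far in a functional assay on DU-145 cells (Homo sapiens) for cytotoxicity, read by MTT assay; on this read-out lower numbers stand for stronger inhibition and higher numbers for weaker inhibition:
Compound 1, `CC(C)=CC[C@@H](OC(=O)CCO)C1=CC(=O)c2c(O)ccc(O)c2C1=O`, gives 55300 nM.
Compound 2, `COC(C)CO[C@H](CC=C(C)C)C1=CC(=O)c2c(O)ccc(O)c2C1=O`, gives 16600 nM.
Compound 3, `CCCCC(O)CC(=O)O[C@H](CC=C(C)C)C1=CC(=O)c2c(O)ccc(O)c2C1=O`, gives 45300 nM.

Compound 3 holds the second highest of these three numbers. It sits close to compound 1, the change being a 1.2-fold lower number from compound 1 to compound 3 (0.09 log units; within the scatter), and further from compound 2, where the change is a 2.7-fold higher number from compound 2 to compound 3 (0.44 log units; beyond the scatter).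

Compound 4, `CC[C@](C)(O)CC(=O)O[C@H](CC=C(C)C)C1=CC(=O)c2c(O)ccc(O)c2C1=O`, differs from compound 3 in one place: 1-hydroxy-1-methylpropyl in place of 1-hydroxypentyl on a saturated chain carbon bound to a carbonyl carbon. The chain that carries the hydroxyl is shortened and gains a methyl on the carbon that bears that hydroxyl, so that this carbon becomes a defined stereocentre.

For the measured compounds named here, only one measured step touches the same chain: a 1.2-fold lower number from compound 1 to compound 3 (0.09 log units; within the scatter), where adding a butyl to the hydroxyl-bearing carbon left the number within the scatter. Going by the values given here, no measured pair tests a methyl on that carbon or a shorter chain. Lengthening the chain did not move the number, so shortening it with a methyl added is expected to leave it near where compound 3 stands; the expected step is a 1.0-fold lower number from compound 3 to compound 4 (0.00 log units; within the scatter), no larger than the scatter.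

Compound 4 is therefore estimated at 45000 nM, within a range from 20000 nM to 100000 nM.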

Compound 4, half-maximal inhibitory concentration: 20500 nM
Beside the measured number, compound 4's estimate is 2.2-fold (0.34 log units) above it, and the stated range covers the measured number.
By their numbers in this assay, from the lowest: compounds 2 and 4 (each within the scatter of the next); then compounds 3 and 1 (each within the scatter of the next).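

In this assay, replacing 1-hydroxypentyl with 1-hydroxy-1-methylpropyl on the saturated chain carbon bound to the carbonyl carbon gives a 2.2-fold lower number from compound 3 to compound 4 (0.34 log units; beyond the scatter), and the replacement of hydroxymethyl at that same place gives a 2.7-fold lower number from compound 1 to compound 4 (0.43 log units; beyond the scatter), so this part of the hydroxy ester chain can move the number beyond the scatter, which the butyl addition in a 1.2-fold lower number from compound 1 to compound 3 (0.09 log units; within the scatter) did not do. Swapping 2-methoxypropyl on the oxygen for (2-hydroxy-2-methylbutyl)carbonyl gives a 1.2-fold higher number from compound 2 to compound 4 (0.09 log units; within the scatter), so these two quite different side chains cannot be told apart on this read-out. There is no supporting evidence here that explains why the number moved.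

The step from 1-hydroxypentyl to 1-hydroxy-1-methylpropyl alters the chain length and adds a methyl on the hydroxyl-bearing carbon in a single move, so the compounds shown cannot say which of the two matters, or whether the defined stereocentre does. From the compounds shown here alone, it also remains open whether the opposite arrangement at that stereocentre, or an amine or a methoxy group in place of the hydroxyl on that carbon, would give a similar number.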